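Clearance of Quinoline Sulfones: Estimating a Methoxyphenyl Analogue

This account rests on a few compounds, and the source may have more. Where it says the series, first, only, none or still open, it means among the compounds named here.

Measured compounds:
Compound 1, `O=S(=O)(c1ccc(F)c(F)c1)c1cnc2c(F)cccc2c1-c1ccc(Cl)cc1`, 0.28 mL/min
Compound 2, `O=S(=O)(c1ccc(F)c(F)c1)c1cnc2c(F)cccc2c1-c1cccc(F)c1`, 1.28 mL/min
Compound 3, `O=S(=O)(c1cc(Cl)cc(Cl)c1)c1cnc2c(F)cccc2c1-c1cccc(F)c1`, 1.08 mL/min

In an ADME assay on microsomes from liver (Homo sapiens) for metabolic stability, tested at 2.5 uM (a lower number here means slower removal, a higher number faster removal of the compound), compound 2 gives the highest of the three numbers. Its nearest neighbour is compound 3, a 1.2-fold lower number from compound 2 to compound 3 (0.07 log units; within the scatter), a gap within the scatter, so the two cannot be ranked. The furthest is compound 1, a 4.6-fold higher number from compound 1 to compound 2 (0.66 log units; beyond the scatter), a gap beyond the scatter.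

Compound 4 is `COc1ccc(-c2c(S(=O)(=O)c3ccc(F)c(F)c3)cnc3c(F)cccc23)cc1`. It differs from compound 2 in one place: 4-methoxyphenyl in place of 3-fluorophenyl on an aromatic carbon.

Going by the values given here, the only measured step at this position is a 4.6-fold higher number from compound 1 to compound 2 (0.66 log units; beyond the scatter), which shows that the group on the aromatic carbon of the shared core can move the number by a modest amount. The step from compound 2 to compound 3 changes a different part of the molecule and gives no information about the ring exchanged here. Among the compounds with values here, no measured compound carries a 4-methoxyphenyl, so no direct precedent exists for the size or direction of the change.

Compound 4 is therefore expected to show a step of a 1.3-fold higher number from compound 2 to compound 4 (0.10 log units; within the scatter), lying within the scatter of compound 2. The value of compound 4 in this assay is estimated at 1.6 mL/min, with a range from 0.7 mL/min to 3.6 mL/min.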

Compound 4, intrinsic clearance in a liver preparation (reported as CLH), per the amount of preparation that the assay uses: 2.12 mL/min
Estimate against measurement, compound 4: 1.3-fold (0.12 log units) below; low and high end bracket the measured number.
By their numbers in this assay, from the lowest: compound 1; then compounds 3, 2 and 4 (each within the scatter of the next).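

In this assay, the exchange at this position gives a 1.7-fold higher number from compound 2 to compound 4 (0.22 log units; within the scatter), so compound 2 and compound 4 cannot be ranked, even though 4-methoxyphenyl brings a hydrogen-bond acceptor that 3-fluorophenyl lacks. Going by these compounds alone, the clearer contrast lies within the pair that carries a single group on the same ring carbon: methoxy in place of chloro gives a 7.6-fold higher number from compound 1 to compound 4 (0.88 log units; beyond the scatter), a gap beyond the scatter and larger than the one measured earlier between compound 1 and compound 2. Among these three compounds, therefore, the separation comes from compound 1 alone, and the number at this position depends on the identity of the group and not merely on where on the ring it stands, although nothing available accounts for the difference between chloro and methoxy.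

What the compounds shown leave open is whether 4-chlorophenyl is unusual here or whether other groups at the same ring carbon, such as fluoro, methyl or a longer ether chain, would fall close to compound 1 or to compound 4. From the compounds shown here alone, it also remains open whether the gap between chloro and methoxy would persist with 3,5-dichlorophenyl on the sulfonyl sulfur.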